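Swapping the benzyl aryl group on the thiazole-linked benzamide series

The source may report more compounds than this note shows. Statements on the series, on what has been measured and on what is new or still open speak of the compounds shown alone.

Of the compounds shown here, two of one series have been measured in a functional assay on cells for agonist activity at G-protein coupled receptor 52 (Homo sapiens), read by AlphaScreen and cAMP accumulation, with a stated time of 30 min; on this read-out lower numbers stand for smaller maximal responses and higher numbers for larger maximal responses. Compound 1 `Cc1nc(Cc2cccc(C(F)(F)F)c2)sc1-c1ccc(C(N)=O)c(C(C)C)c1` carries an isopropyl-substituted benzamide and a trifluoromethylphenyl on the saturated chain carbon, and in this assay compound 1 reaches 63%. Compound 2 `COc1cccc(Cc2nc(C)c(-c3ccc(C(N)=O)c(C)c3)s2)c1` carries the methyl-substituted benzamide together with a 3-methoxyphenyl, and in this assay compound 2 reaches 85%. Among the compounds with values here, of the two numbers known, compound 2 stands highest, with compound 1 lying beyond the scatter below it.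

Compound 3 `Cc1cc(-c2sc(Cc3ccc(Cl)cc3)nc2C)ccc1C(N)=O` is the next compound for this assay. Against compound 2 the change is 4-chlorophenyl in place of 3-methoxyphenyl on a saturated chain carbon bound to an aromatic carbon; the benzamide part of compound 2 is kept. Within the data shown here, no step between two measured compounds isolates this kind of exchange, and the two measured compounds differ in more than one place, so no direct guide exists. On that footing a step from compound 2 to compound 3 of about a number 7 percentage points lower from compound 2 to compound 3 (within the scatter) is expected in this assay, that is, nothing beyond the scatter. For compound 3 the expected value in this assay is therefore 78%, within a range of 58% to 98%.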

Compound 3, largest response reached (Emax), in percent of the reference or control that the assay uses: 60%
Compound 3: middle estimate off by 18 percentage points, on the high side, and the stated range covers the measured number.
By their numbers in this assay, from the lowest: compounds 3 and 1 (each within the scatter of the next); then compound 2.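

With the benzamide part of compound 2 kept, 4-chlorophenyl in place of 3-methoxyphenyl on a saturated chain carbon bound to an aromatic carbon gives a number 25 percentage points lower from compound 2 to compound 3 (beyond the scatter) in this assay, so the maximal response is sensitive to the identity of the aryl group at this position. Compound 1 and compound 2 differ in more than one place and could not show this, which makes the present exchange the only one in the series that isolates a single position. The exchange replaces a group with one hydrogen-bond acceptor by a group with none, but no measurement available here bears on why the response falls.

The step leaves open whether it follows the change of substituent or the change of its place on the ring, a question that 4-methoxyphenyl and 3-chlorophenyl on the same carbon would address. It also leaves open how far this position tolerates other groups, such as an unsubstituted phenyl or a pyridine ring, and whether the isopropyl of compound 1 would alter the effect of the same exchange.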